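This account rests on a few compounds, and the source may have more. Where it says the series, first, only, none or still open, it means among the compounds named here.

Of the compounds shown here, three that share one core have been measured in an assay on tissue (HeLa cells) for inhibition of Indoleamine 2,3-dioxygenase 1 (Homo sapiens), read by spectrophotometry; on this read-out higher numbers stand for weaker inhibition and lower numbers for stronger inhibition. Compound 1 `O/N=C(/Nc1ccccc1)c1ccc2occc2c1` gives 19000 nM. Compound 2 `O/N=C(/NCc1cccc(Cl)c1)c1ccc2occc2c1` gives 5800 nM, the lowest of the three numbers: compound 3 is the nearest and compound 1 the furthest, and both stand beyond the usual scatter from it. Compound 3 `O/N=C(/NCc1ccc(F)c(Cl)c1)c1ccc2occc2c1` gives 17600 nM; it differs from compound 2 only by a fluoro in place of hydrogen on an aromatic carbon, a step of a 3.0-fold higher number from compound 2 to compound 3 (0.48 log units; beyond the scatter).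

Compound 4 `O/N=C(/NCC1CC1)c1ccc2occc2c1` has not yet been measured. It differs from compound 2 by cyclopropyl in place of 3-chlorophenyl on a saturated chain carbon bound to an amine nitrogen. Within the data shown here, no measured step removes the aromatic ring or the chlorine, so nothing bears on this change directly. Among the measured compounds shown here, the one step that touches the same ring, from compound 2 to compound 3, shows that even a small change there moved the number beyond the scatter, and here the whole 3-chlorophenyl is taken away. A larger loss is therefore expected, and the step from compound 2 to compound 4 is estimated at a 2.8-fold higher number from compound 2 to compound 4 (0.44 log units; beyond the scatter). Compound 4 is expected to give about 16000 nM, within a range from 5000 nM to 50000 nM.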

Compound 4, half-maximal inhibitory concentration: > 30000 nM
Compound 4: no number, only a limit (the forecaster's own chance of this, stated with the estimate: 15%); at least 1.8-fold (0.27 log units) between middle value and limit.
By their numbers in this assay, from the lowest: compound 2; then compounds 3 and 1 (each within the scatter of the next). At a limit, above all of these: compound 4.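

In this assay, compound 4 gives no number, only a limit of the assay: the limit of > 30000 nM in this assay, at which 1 of the 4 values shown sits.

Even so, the limit is enough to read one step: cyclopropyl in place of 3-chlorophenyl on a saturated chain carbon bound to an amine nitrogen gives an at least 5.1-fold higher number from compound 2 to compound 4 (0.71 log units; beyond the scatter), which shows that replacing the whole aromatic ring at this place costs more than the scatter, as the smaller change on that ring also did. The other new step, cyclopropylmethyl in place of phenyl on an amine nitrogen, reads an at least 1.5-fold higher number from compound 1 to compound 4 (0.19 log units; that floor lies within the scatter), and since its floor lies within the scatter, it sets no order between those two compounds.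

The true number of compound 4 stays unknown, and the compounds shown cannot separate what the loss of the chlorine contributes from what the loss of the aromatic ring contributes. An unsubstituted benzyl group at this place would speak to the first of these, and a longer chain in place of the cyclopropyl would show whether any non-aromatic group can keep a measurable number here.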